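Aryl sulfonamides on a bipiperidine: dropping the biaryl

The source may report more compounds than this note shows. Statements on the series, on what has been measured and on what is new or still open speak of the compounds shown alone.

Measured so far:
compound 1, `CC1CCN(C2CCN(S(=O)(=O)c3cnc(Cl)s3)CC2)CC1` — 1800 nM
compound 2, `CC1CCN(C2CCN(S(=O)(=O)c3cccc(-c4ccccc4F)c3)CC2)CC1` — 10 nM

In a functional assay on DLD-1 cells (Homo sapiens) for antiproliferative activity, read by CellTiter-Glo, with a stated time of 72 h (on this read-out lower numbers stand for stronger inhibition and higher numbers for weaker inhibition), compound 2 gives the lower of the two numbers; compound 1 gives 1800 nM in this assay, and the two values lie well apart, beyond the usual scatter. Among the measured compounds shown here, no single-change step between measured compounds is available, so nothing is known yet about how much of the potency of compound 2 rests on its 2-fluorophenyl group.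

For the measured compounds named here, compound 3, `Cc1cccc(S(=O)(=O)N2CCC(N3CCC(C)CC3)CC2)c1`, is the first test of that question: methyl in place of 2-fluorophenyl on an aromatic carbon. The change removes most of the aryl substituent and keeps only a small group in its place. Going by the values given here, with only one pair of measured values to lean on, the expected step from compound 2 to compound 3 is a loss of potency in this assay, clearly beyond the scatter, a 30-fold higher number from compound 2 to compound 3 (1.48 log units; beyond the scatter). Compound 3 is therefore estimated at 300 nM, within 60 nM to 1500 nM.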

Compound 3, half-maximal inhibitory concentration: 25 nM
For compound 3 the middle estimate is 12-fold (1.08 log units) above the measured one, and the stated range ends above it.
By their numbers in this assay, from the lowest: compound 2; then compound 3; then compound 1.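

In this assay most of the potency of compound 2 does not rest on its 2-fluorophenyl group: methyl in its place gives a 2.5-fold higher number from compound 2 to compound 3 (0.40 log units; beyond the scatter), a modest step though beyond the scatter. The group on the sulfonyl sulfur weighs far more in this comparison, since 3-methylphenyl in place of 2-chloro-1,3-thiazol-5-yl gives a 72-fold lower number from compound 1 to compound 3 (1.86 log units; beyond the scatter), a large step that a single methyl-bearing benzene ring is enough to deliver. Nothing at hand bears on the origin of either step.

Still open, on these data alone, is what a bare hydrogen, a chlorine or a methoxy group on that aromatic carbon would give, and so whether the methyl itself contributes. Also open, as far as these compounds go, is how an amine or a carboxylic acid at the same place would read out in this assay.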